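The source may hold more compounds than are shown below. What is called first, only, known or untested is meant among the compounds shown, and "the series" means these compounds.

Measured in a functional assay on L1210 cells (Mus musculus) for antiproliferative activity, with a stated time of 48 h; a higher number here means a weaker inhibitor, a lower number a stronger inhibitor:
compound 1 `C=C(Br)C(=O)Nc1ccc(/C=C/C(=O)c2ccccc2)cc1`: 5000 nM
compound 2 `C=C(Br)C(=O)Nc1ccc(/C=C/C(=O)c2ccc(F)cc2)cc1`: 1600 nM
compound 3 `C=C(Br)C(=O)Nc1ccc(/C=C/C(=O)c2ccc(I)cc2)cc1`: 3400 nM

Compound 1 stands at the upper end of these numbers: a 1.5-fold lower number from compound 1 to compound 3 (0.17 log units; within the scatter) leaves it in the same range, while a 3.1-fold lower number from compound 1 to compound 2 (0.49 log units; beyond the scatter) is the larger move. Compound 4 `Nc1ccc(/C=C/C(=O)c2ccccc2)cc1` differs from compound 1 by hydrogen in place of (1-bromoethenyl)carbonyl on a nitrogen on an aromatic ring. Going by the values given here, no measured step touches this nitrogen. The steps available, including a 2.1-fold higher number from compound 2 to compound 3 (0.33 log units; beyond the scatter), all concern a halogen or hydrogen on an aromatic carbon, and they remain modest or within the scatter. They therefore set no size for the new change, and all three measured compounds carry the group that leaves. Losing that whole group is expected to move the number upward in this assay, by clearly more than any halogen step. The expected step is a 6.0-fold higher number from compound 1 to compound 4 (0.78 log units; beyond the scatter). Compound 4 is estimated at 30000 nM, with an expected range of 10000 nM to 90000 nM.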

Compound 4, half-maximal inhibitory concentration: 88000 nM
Estimate against measurement, compound 4: 2.9-fold (0.47 log units) below; the range from low to high includes it.
By their numbers in this assay, from the lowest: compound 2; then compounds 3 and 1 (each within the scatter of the next); then compound 4.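

In this assay, the nitrogen on the aromatic ring responds far more strongly than the aromatic carbon probed by the halogen steps: hydrogen in place of (1-bromoethenyl)carbonyl gives an 18-fold higher number from compound 1 to compound 4 (1.25 log units; beyond the scatter), whereas the largest halogen change from the same parent gives a 3.1-fold lower number from compound 1 to compound 2 (0.49 log units; beyond the scatter). The whole group on this nitrogen therefore matters much more to the number than the choice of hydrogen, fluoro or iodo on the aromatic carbon, although compound 4 still gives a measured value rather than a limit. The data offer no evidence on why removing this group has so large an effect.

From the compounds shown here alone, it remains open which part of the group carries the effect, the bromine, the double bond or the carbonyl on the nitrogen; an acetyl or a plain propenoyl group there would help separate them. The compounds shown also leave open whether the fluoro and iodo steps would hold on the free amine.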